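Serine to Glutamate Side Chain on a Shared Core

The source may report more compounds than this note shows. Statements on the series, on what has been measured and on what is new or still open speak of the compounds shown alone.

Of the compounds shown here, three built on a shared core have been tested in a functional assay on the whole organism (Tail, strain ICR) with Mus musculus as the target, in the tail flick test, with a stated time of 120 min, at a dose of 25 umol/kg by the oral route; a lower number here means a weaker effect, a higher number a stronger effect of the compound at the dose given. Compound 1, `O=C(CN(c1nc(Cl)nc2[nH]cnc12)C1CC1)N[C@@H](CO)C(=O)OCc1ccccc1`, gives 34.5%. Compound 2, `O=C(O)[C@@H]1CCCN1C(=O)CN(c1nc(Cl)nc2[nH]cnc12)C1CC1`, gives 23.6%. Compound 3, `O=C(CN(c1nc(Cl)nc2[nH]cnc12)C1CC1)N[C@@H](CO)C(=O)O`, gives 39%, the highest number of the three, though its gap to compound 1 stays within the scatter; the step of a number 4.5 percentage points higher from compound 1 to compound 3 (within the scatter) carries that change from benzyl ester to free acid, and the step of a number 15.4 percentage points higher from compound 2 to compound 3 (beyond the scatter) carries the exchange of the amino acid portion.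

Compound 4, `O=C(O)CC[C@H](NC(=O)CN(c1nc(Cl)nc2[nH]cnc12)C1CC1)C(=O)O`, differs from compound 3 by carboxymethyl in place of hydroxy on a saturated chain carbon, two bonds along the chain from an amide-type nitrogen and a carbonyl carbon. Neither measured step copies this change: the step from compound 1 to compound 3 altered only the ester, and the step from compound 2 to compound 3 swapped one amino acid portion for another and gave a modest gain. Taken together they suggest that a change at this outer part of the chain moves the read-out little. Compound 4 is therefore expected to stay near compound 3, with an estimated step of a number 3 percentage points lower from compound 3 to compound 4 (within the scatter), so that compound 4 is estimated at 36%, within a range from 20% to 52%.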

Compound 4, a percentage reported as activity, at one dose (the size of the read-out at that dose, not a potency): 30.1%
Estimate against measurement, compound 4: 5.9 percentage points above; low and high end bracket the measured number.
By their numbers in this assay, from the lowest: compounds 2, 4, 1 and 3 (each within the scatter of the next, the first and the last beyond it).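

This is the first change shown at this saturated chain carbon, two bonds along the chain from an amide-type nitrogen and a carbonyl carbon. In this assay, putting carboxymethyl in place of hydroxy gives a number 8.9 percentage points lower from compound 3 to compound 4 (within the scatter), so this larger group, which carries a carboxylic acid of its own, leaves the read-out indistinguishable from that of the hydroxy compound at this single dose. No measurement here gives a reason for that outcome.

One step cannot show how far this tolerance extends: an amine on the same carbon, a plain methyl group or a longer chain ending in a carboxylic acid might each behave differently. As far as these compounds go, it also remains open whether a benzyl ester of compound 4 would give a read-out close to that of compound 4 itself.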